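Ethyl Gives Way to Chloro on a Shared Core

The source may report more compounds than this note shows. Statements on the series, on what has been measured and on what is new or still open speak of the compounds shown alone.

Of the compounds shown here, three share one core and have been tested in a functional assay on K562 cells (Homo sapiens) for inhibition, read by sulforhodamine B assay, with a stated time of 48 h; on this read-out lower numbers stand for stronger inhibition of growth and higher numbers for weaker inhibition of growth. Compound 1 `CCc1ccc(NC(=S)N/N=C/c2cccs2)cc1` carries an ethyl group on its six-membered carbon ring and gives 1600 nM in this assay. Compound 3 `C=CCNC(=S)N/N=C/c1cccs1` replaces that ring with an allyl chain and gives 6000 nM. Where compound 1 has the carbon ring, a pyridine ring stands in compound 2 `S=C(N/N=C/c1cccs1)Nc1cccnc1`, which gives 16400 nM in this assay. Among these three, compound 1 stands lowest, so it is the strongest inhibitor of growth: compound 3 sits closest, with a higher number that lies beyond the usual scatter, and compound 2 sits furthest, also beyond the scatter.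

Compound 4 `S=C(N/N=C/c1cccs1)Nc1ccc(Cl)cc1` has not yet been measured. It differs from compound 1 in one place: chloro in place of ethyl on an aromatic carbon. Among the measured compounds shown here, no measured pair in this set shows this exact exchange, so the expectation rests on where compound 1 stands and on the small size of the change. The step from compound 1 to compound 4 is expected to be a 1.3-fold lower number from compound 1 to compound 4 (0.12 log units; within the scatter), that is, little or no change beyond the scatter, with a slight lean toward stronger inhibition. Compound 4 is therefore expected to give about 1200 nM in this assay, somewhere between 400 nM and 4000 nM.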

Compound 4, concentration for 50% growth inhibition: 2000 nM
Compound 4: the middle estimate sits 1.7-fold (0.22 log units) below what was measured; the range from low to high includes it.
By their numbers in this assay, from the lowest: compounds 1 and 4 (each within the scatter of the next); then compound 3; then compound 2.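

In this assay the exchange of chloro for ethyl gives a 1.3-fold higher number from compound 1 to compound 4 (0.10 log units; within the scatter) and so leaves the two compounds indistinguishable in growth inhibition. Among the compounds shown here, this is the first direct reading at this position, on an aromatic carbon para to a large group, and it shows that one chlorine atom can stand in place of the two carbons of ethyl with no change that can be read from the numbers. No measurement is available that could account for this match between the two groups.

On these data alone, a single exchange says nothing about groups of a different kind, so it remains open whether an amine, a carboxylic acid or a longer chain at this same place would keep growth inhibition close to that of compound 1, at 1600 nM in this assay. As far as these compounds go, it is also open whether chloro would give a similar number on another carbon of the same ring, since both compounds in this pair carry their group at the one position.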